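From compound 1 to compound 3: a side chain added

The compounds below may be only part of what the source reports. "The series", "measured", "known", "first", "only" and "open" are said of these compounds alone.

compound 1 `Cn1c(N)c(-c2nc3ccccc3[nH]2)c2nc(C#N)c(C#N)nc21`: > 50000 nM
compound 2 `CCCn1c(N)c(-c2nc3ccccc3[nH]2)c2nc(C#N)c(C#N)nc21`: > 50000 nM

In a functional assay on Raji cells (Homo sapiens) for antiproliferative activity, read by MTT assay, with a stated time of 48 h (a higher number here means a weaker inhibitor, a lower number a stronger inhibitor), compound 1 stands at > 50000 nM, which is a limit and not a number. Compound 2 gives > 50000 nM, which is also a limit. The record therefore holds (the limit of > 50000 nM in this assay, at which 2 of the 2 values shown sit), and compound 1 offers no number to start from.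

Compound 3 `CCN(CC)CCCCn1c(-c2c(N)n(C)c3nc(C#N)c(C#N)nc23)nc2ccccc21` keeps the core of compound 1 and changes in one place: 4-(diethylamino)butyl in place of hydrogen on an aromatic nitrogen. This puts 4-(diethylamino)butyl in place of hydrogen on an aromatic nitrogen of a five-membered aromatic ring, next to the ring atom that bears a large group.

Within the data shown here, the only measured step is a step that the two limits leave unreadable from compound 1 to compound 2. It is a different change, ethyl in place of hydrogen on a saturated chain carbon, and it supplies no size to carry over. A readable result in this assay could only lie toward stronger inhibition, so a modest step in that direction is expected, though another limit remains quite possible. The expected step is an at least 2.5-fold lower number from compound 1 to compound 3 (0.39 log units; beyond the scatter). For compound 3 the estimated value is 20000 nM, with an expected range from 4000 nM to 50000 nM.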

Compound 3, half-maximal inhibitory concentration: 600 nM
Beside the measured number, compound 3's estimate is 33-fold (1.52 log units) above it, outside the stated range (below it).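

In this assay, 4-(diethylamino)butyl in place of hydrogen on the aromatic nitrogen of the five-membered aromatic ring gives an at least 83-fold lower number from compound 1 to compound 3 (1.92 log units; beyond the scatter), and compound 3 is the first compound shown with a readable value. Compound 1 gives > 50000 nM, which is a limit and not a number. The earlier change, ethyl in place of hydrogen on a saturated chain carbon, gave a step that cannot be read, and so the earlier compounds gave no sign that the shared core could reach a measurable value in this assay, whereas this nitrogen is now shown to be a place where a single change moves the result well beyond the scatter: the limit of > 50000 nM in this assay, at which 2 of the 3 values shown sit.

What remains open is which part of the side chain goes with this result, for the compounds shown do not separate 4-(diethylamino)butyl from a plain butyl chain, a shorter chain bearing the same amine, or a morpholine in place of the diethylamino group. They also leave open whether the same side chain would give a similar result on compound 2, which carries the longer chain in place of the methyl group of compound 1.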